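Swapping a branched chain for a substituted benzyl

A few compounds are considered here, and "the series" means these few. Any claim that something is new, unique, unknown or untested is made for them only; others in the source may bear on it.

Measured so far:
compound 1 `CCCn1ccc2cc(/C(C)=C/C(=O)Nc3ccccc3OCCCC(=O)O)ccc21` gives 190 nM in an assay on Prostate gland for inhibition of steroid 5-alpha-reductase (Rattus norvegicus); a lower number here means a stronger inhibitor, a higher number a weaker inhibitor
compound 2 `CCCCC(C)n1ccc2cc(/C(C)=C/C(=O)Nc3ccccc3OCCCC(=O)O)ccc21` gives 6 nM in this assay

Going by the values given here, compound 2 stands at the lower of the two numbers so far, with compound 1 as its only neighbour. Among the compounds with values here, the one measured step, a 32-fold lower number from compound 1 to compound 2 (1.50 log units; beyond the scatter), changed the group on the aromatic nitrogen, and compound 3 `C/C(=C\C(=O)Nc1ccccc1OCCCC(=O)O)c1ccc2c(ccn2Cc2ccc(C(F)(F)F)cc2)c1` alters the same place again: 4-(trifluoromethyl)benzyl in place of 1-methylpentyl on an aromatic nitrogen. That earlier step bears on compound 3 only loosely: it shows that a larger group on the aromatic nitrogen went with a lower number, but it says nothing about an aromatic ring carrying trifluoromethyl in place of a branched chain. A step of modest size in either direction is plausible, and none beyond the scatter is the simplest expectation. Compound 3 is therefore expected at 8 nM, between 2 nM and 40 nM, which means an expected step of a 1.3-fold higher number from compound 2 to compound 3 (0.12 log units; within the scatter).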

Compound 3, half-maximal inhibitory concentration: 300 nM
Estimate against measurement, compound 3: 38-fold (1.57 log units) below; measured number above the stated range.
By their numbers in this assay, from the lowest: compound 2; then compounds 1 and 3 (each within the scatter of the next).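

In this assay, the size of the group on the aromatic nitrogen does not settle the outcome: 4-(trifluoromethyl)benzyl has more heavy atoms than 1-methylpentyl and contains an aromatic ring, yet the change gives a 50-fold higher number from compound 2 to compound 3 (1.70 log units; beyond the scatter) in this series. The other new step, a 1.6-fold higher number from compound 1 to compound 3 (0.20 log units; within the scatter) with its small gap, shows that the low number of compound 2 does not carry over to every larger group, since this benzyl group cannot be told apart from propyl. Nothing measured here accounts for the difference between 1-methylpentyl and 4-(trifluoromethyl)benzyl.

The compounds shown do not separate the part played by the trifluoromethyl group from that of the ring. Nor do they show whether a plain benzyl or a branched 1-phenylethyl group would match compound 2 or compound 3.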